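Thiourea Benzamides Against Leukaemia Cells: A Nitro Replacement

The source may report more compounds than this note shows. Statements on the series, on what has been measured and on what is new or still open speak of the compounds shown alone.

Compound 1, `NC(=O)c1c(NC(=O)c2ccccc2Cl)sc2c1CCN(C(=S)Nc1ccccc1C(F)(F)F)C2`, gives 10600 nM in a functional assay on HL-60 cells (Homo sapiens) for antiproliferative activity, with a stated time of 24 h; a lower number here means a stronger inhibitor, a higher number a weaker inhibitor.
Compound 2, `NC(=O)c1c(NC(=O)c2ccccc2I)sc2c1CCN(C(=S)Nc1ccccc1Cl)C2`, gives 8560 nM.

In this assay compound 2 and compound 1 sit within the scatter of each other, so neither can be called the stronger inhibitor. Compound 3, `NC(=O)c1c(NC(=O)c2cccc([N+](=O)[O-])c2)sc2c1CCN(C(=S)Nc1ccccc1Cl)C2`, is not yet measured. It differs from compound 2 in one place: 3-nitrophenyl in place of 2-iodophenyl on a carbonyl carbon. Among the compounds with values here, no measured pair shows a change of this kind, so its effect is open; a modest step in either direction, or none beyond the scatter, would fit what is known. Compound 3 is expected to give about 12000 nM (range 4000 nM to 40000 nM), an estimated step of a 1.4-fold higher number from compound 2 to compound 3 (0.15 log units; within the scatter).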

Compound 3, half-maximal inhibitory concentration: 7040 nM
Compound 3: the middle estimate sits 1.7-fold (0.23 log units) above what was measured; measured number inside the range.
By their numbers in this assay, from the lowest: compounds 3, 2 and 1 (each within the scatter of the next).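

In this assay, 3-nitrophenyl in place of 2-iodophenyl on a carbonyl carbon gives a 1.2-fold lower number from compound 2 to compound 3 (0.08 log units; within the scatter), so this position accepts a different aryl group with no change beyond the scatter. The entering group carries hydrogen-bond acceptors that the leaving group lacks, yet the number does not respond beyond the scatter. Nothing available explains this result.

Going by these compounds, it remains open whether an amine or a carboxylic acid in place of the nitro group would move the number beyond the scatter. Also open, on these data alone, is whether any replacement of this aryl group on the carbonyl carbon does so.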